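A few compounds are considered here, and "the series" means these few. Any claim that something is new, unique, unknown or untested is made for them only; others in the source may bear on it.

Compound 3 `CN(C)c1ccc(-c2cccc(NC(=O)Oc3ccccc3)c2)cc1` gives 73000 nM in an assay on COS-7 cells for inhibition of patatin-like phospholipase domain-containing protein 2 (Mus musculus); a lower number here means a stronger inhibitor, a higher number a weaker inhibitor. Among the three measured compounds it stands second highest, near compound 1 `CN(C)c1ccc(-c2cccc(N)c2)cc1` with 100000 nM and far from compound 2 `COC(=O)Nc1cccc(-c2ccc(N(C)C)cc2)c1` with 5000 nM. The change to compound 4 `CN(C)c1ccc(-c2cccc(NC(=O)N3CCOCC3)c2)cc1` is morpholin-4-yl in place of phenoxy on a carbonyl carbon. Going by the values given here, two measured steps bear on this position: a 20-fold lower number from compound 1 to compound 2 (1.30 log units; beyond the scatter) and a 15-fold higher number from compound 2 to compound 3 (1.16 log units; beyond the scatter), both large. The second shows that exchanging the methyl on the oxygen for phenyl made a much weaker inhibitor, so the group on the carbonyl carbon clearly shifts the read-out. Among the compounds with values here, replacing phenoxy by a ring with two hetero atoms is a new kind of change, and a urea is not a carbamate, so the direction rests on only one comparison. A lower number is nevertheless expected for compound 4, estimated at 12000 nM with a range of 3000 nM to 50000 nM. This expectation means a 6.1-fold lower number from compound 3 to compound 4 (0.78 log units; beyond the scatter).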

Compound 4, half-maximal inhibitory concentration: > 200000 nM
Compound 4: no number, only a limit; the forecaster's own chance of this, stated with the estimate: 10%; middle value at least 16-fold (1.22 log units) away from the limit.
By their numbers in this assay, from the lowest: compound 2; then compounds 3 and 1 (each within the scatter of the next). At a limit, above all of these: compound 4.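

Compound 4 carries no number, only a limit of the assay: the limit of > 200000 nM in this assay, at which 1 of the 4 values shown sits. Even so, morpholin-4-yl on the carbonyl carbon gives a weaker inhibitor than either earlier group there, with an at least 2.7-fold higher number from compound 3 to compound 4 (0.43 log units; beyond the scatter) and an at least 40-fold higher number from compound 2 to compound 4 (1.60 log units; beyond the scatter). Set against the parent with hydrogen on the nitrogen, the change gives an at least 2.0-fold higher number from compound 1 to compound 4 (0.30 log units; that floor lies within the scatter), a floor that does not separate the two, so among these three groups only methoxy gives a clear gain, and a ring on the carbonyl carbon, aromatic or not, goes with weak inhibition. As far as these compounds go, whether a small amine such as dimethylamino, or a slightly longer chain such as ethoxy, on the carbonyl carbon would match compound 2 stays open.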